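The compounds below may be only part of what the source reports. "The series", "measured", "known", "first", "only" and "open" are said of these compounds alone.

Of the compounds shown here, three have so far been measured in an ADME assay for permeability, using PAMPA, at pH 7.4; on this read-out lower numbers stand for lower permeability and higher numbers for higher permeability. Compound 1 `Cc1cc(NC(=O)Nc2ccc(C)c(Cl)c2)c2ccccc2n1` gives 262 10^-6 cm/s, compound 2 `COc1ccc(NC(=O)Nc2cc(C)nc3ccccc23)cc1` gives 787 10^-6 cm/s, and compound 3 `Cc1cc(NC(=O)Nc2ncccc2C)c2ccccc2n1` gives 369 10^-6 cm/s. Compound 3 thus stands second highest of the three numbers: its value lies within the scatter of compound 1, while compound 2 sits beyond the scatter above it. Compound 4 `Cc1ccc(NC(=O)Nc2cc(C)nc3ccccc23)cc1` differs from compound 3 in one place: 4-methylphenyl in place of 3-methylpyridin-2-yl on an amide-type nitrogen. Among the compounds with values here, no measured pair shows this change, so its size is open. Because compound 2 gives 787 10^-6 cm/s, an upward move in this assay is expected, though one that may still fall within the scatter. Compound 4 is therefore estimated at 550 10^-6 cm/s, with a range from 300 10^-6 cm/s to 950 10^-6 cm/s, an expected step of a 1.5-fold higher number from compound 3 to compound 4 (0.17 log units; within the scatter).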

Compound 4, apparent permeability: 669 10^-6 cm/s
For compound 4 the middle estimate is 1.2-fold (0.09 log units) below the measured one; low and high end bracket the measured number.
By their numbers in this assay, from the lowest: compounds 1, 3, 4 and 2 (each within the scatter of the next, the first and the last beyond it).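

In this assay there is a 1.8-fold higher number from compound 3 to compound 4 (0.26 log units; within the scatter) with 4-methylphenyl in place of 3-methylpyridin-2-yl on an amide-type nitrogen, so this exchange of rings stays inside the scatter. Methyl in place of methoxy on an aromatic carbon brings a 1.2-fold lower number from compound 2 to compound 4 (0.07 log units; within the scatter) and also stays inside it, while hydrogen in place of chloro on an aromatic carbon brings a 2.6-fold higher number from compound 1 to compound 4 (0.41 log units; beyond the scatter) and, alone among these three steps, passes modestly beyond the scatter. From the compounds shown here alone, how an amine or a carboxylic acid on the same ring would read remains open. Nothing given here accounts for the size of these steps.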